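A few compounds are considered here, and "the series" means these few. Any claim that something is new, unique, unknown or untested is made for them only; others in the source may bear on it.

Of the compounds shown here, three of a shared core have been measured in a functional assay on the whole organism with Rattus norvegicus as the target, at a dose of 1 mg/kg by the oral route; on this read-out lower numbers stand for a weaker effect and higher numbers for a stronger effect at the one dose given. Compound 1 `COc1cc(C(=O)Nc2nn[nH]n2)nc(-c2ccc(Cl)cc2)c1` gives 0% in this assay. Compound 2 `Cc1ccc(-c2cccc(C(=O)Nc3nn[nH]n3)n2)cc1` gives 67%. Compound 3 `Nc1ccc(-c2cccc(C(=O)Nc3nn[nH]n3)n2)cc1` gives 62%, the second highest of the three numbers: compound 2 lies nearest, and the step of a number 5 percentage points lower from compound 2 to compound 3 (within the scatter) is within the scatter, while compound 1 lies far below, beyond the scatter. Compound 1 differs from compound 2 in two places at once, a methoxy group on the core and a chlorophenyl group, so its low number cannot be tied to either change alone.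

Compound 4 `Cc1cc(C(=O)Nc2nn[nH]n2)nc(-c2ccc(N)cc2)c1` differs from compound 3 by methyl in place of hydrogen on an aromatic carbon. Within the data shown here, no measured step changes this carbon of the core, so no step bears directly on it. Among the measured compounds shown here, the only single step known, from compound 2 to compound 3, touched the phenyl group and stayed within the scatter. A small group added to the core is therefore expected to give no step beyond the scatter, though compound 1 shows that changes on the core can come with a very low number, which widens the range downward. For compound 4 the expected step in this assay is a number 12 percentage points lower from compound 3 to compound 4 (beyond the scatter), giving an estimate of 50%, between 15% and 80%.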

Compound 4, a percentage reported as inhibition, in the whole organism at one dose (the size of the read-out at that dose, not a potency): 75%
Beside the measured number, compound 4's estimate is 25 percentage points below it, and the stated range covers the measured number.
By their numbers in this assay, from the lowest: compound 1; then compounds 3, 2 and 4 (each within the scatter of the next, the first and the last beyond it).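

In this assay, putting a methyl group on the aromatic carbon opposite the ring nitrogen gives a number 13 percentage points higher from compound 3 to compound 4 (beyond the scatter), a modest step and the first single change measured at this carbon of the shared core. This shows that the carbon need not stay unsubstituted: with the 4-aminophenyl group in place, a methyl group here keeps the effect at the one dose given and even adds slightly to it, so a group on this carbon does not by itself come with a very low number. Nothing measured here explains why the methyl group raises the number.

Going by these compounds, with only hydrogen and methyl compared directly at this carbon, it remains open whether an ethyl group, a longer chain or a hydroxy group would hold the number, raise it further or lose the effect. Also open, on these data alone, are whether the methyl group would give a similar step alongside the 4-methylphenyl group of compound 2, and whether the methoxy group or the chlorophenyl group of compound 1 accounts for its 0%.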